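Aryl thioether piperazine acetic acids: glycine transporter inhibition

The source may hold more compounds than are shown below. What is called first, only, known or untested is meant among the compounds shown, and "the series" means these compounds.

Compound 1 `COc1ccc(Sc2ccccc2N2CCN(CC(=O)O)C(C)C2)cc1`: 1700 nM
Compound 2 `COc1ccc(Sc2ccc(Cl)cc2N2CC(C)N(CC(=O)O)CC2C)cc1`: 1700 nM
Compound 3 `Cc1ccc(Sc2ccccc2N2CC(C)N(CC(=O)O)CC2C)cc1`: 550 nM

Three members of the series have been measured in an assay for inhibition of sodium- and chloride-dependent glycine transporter 1 (Homo sapiens); on this read-out higher numbers stand for weaker inhibition and lower numbers for stronger inhibition. Compound 1 gives 1700 nM in this assay, and compound 2 gives 1700 nM. Compound 3 gives 550 nM, the lowest of the three numbers; its gap to compound 1 and to compound 2 is alike and lies beyond the scatter, so compound 3 counts as the strongest inhibitor among the three measured.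

Compound 4 `CC(=O)Nc1ccc(Sc2ccccc2N2CC(C)N(CC(=O)O)CC2C)cc1` is not yet measured. It differs from compound 3 in one place: acetamido in place of methyl on an aromatic carbon. Going by the values given here, no measured pair shows this exchange, so the size of the step cannot be taken from the series. The step from compound 3 to compound 4 is expected to be a 2.2-fold higher number from compound 3 to compound 4 (0.34 log units; beyond the scatter), a moderate move toward weaker inhibition, possibly not beyond the scatter. Compound 4 is therefore estimated at 1200 nM in this assay, with a range from 400 nM to 4000 nM.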

Compound 4, half-maximal inhibitory concentration: 22000 nM
Estimate against measurement, compound 4: 18-fold (1.26 log units) below, and the stated range ends below it.
By their numbers in this assay, from the lowest: compound 3; then compounds 1 and 2 (each within the scatter of the next); then compound 4.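

In this assay, going by these compounds alone, this position, para to a large group on the aromatic ring, turns out to be far from indifferent to what it carries, which the earlier compounds could not show: acetamido in place of methyl gives a 40-fold higher number from compound 3 to compound 4 (1.60 log units; beyond the scatter). The exchange replaces 1 heavy atom with 4 and brings in 1 hydrogen-bond donor and 1 hydrogen-bond acceptor, and this single pair cannot separate the contributions of these changes. Nothing measured on these compounds explains the size of the step.

Open, on these data alone, is whether an ethyl or longer alkyl chain here, which adds atoms without the amide, would be tolerated better or worse than acetamido. An amino group or a hydroxyl in the same place would test the hydrogen-bonding atoms without the added bulk of acetamido.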